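The source may report more compounds than this note shows. Statements on the series, on what has been measured and on what is new or still open speak of the compounds shown alone.

Measured compounds and values:
compound 1, `COc1ccc(-n2ncnc2-c2cc(OC)c(OC)c(OC)c2)cc1`: 7400 nM
compound 2, `COc1cc(-n2ncnc2-c2ccccc2)cc(OC)c1OC`: > 10000 nM

Among the measured compounds shown here, in a functional assay on MCF7 cells (Homo sapiens) for antiproliferative activity, read by MTT assay, with a stated time of 72 h (on this read-out lower numbers stand for stronger inhibition and higher numbers for weaker inhibition), compound 1 gives 7400 nM, the only actual number in this small set. Compound 2 does not give a number at all, only a limit of the assay: the limit of > 10000 nM in this assay, at which 1 of the 2 values shown sits. For the measured compounds named here, the two measured compounds differ in more than one place, so no single step between them can be read off. Going by the values given here, the only thing their two values show is that compound 1 sits at a measured number while compound 2 sits at a limit.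

Compound 3, `COc1cc(-c2ncnn2-c2ccc(N)cc2)cc(OC)c1OC`, differs from compound 1 by amino in place of methoxy on an aromatic carbon. Among the compounds with values here, with no measured step to lean on, the expected change is small, no further than the scatter, in no fixed direction. The step of a 1.5-fold lower number from compound 1 to compound 3 (0.17 log units; within the scatter) is therefore expected to be modest. Compound 3 is estimated at 5000 nM, with a likely range from 1500 nM to 20000 nM.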

Compound 3, half-maximal inhibitory concentration: > 10000 nM
Compound 3: only a limit was reported; the forecaster's own chance of this, stated with the estimate: 25%; middle value at least 2.0-fold (0.30 log units) from the limit.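

Among the compounds shown here, the first single change that can be read in this assay is 4-methoxyphenyl to 4-aminophenyl, which gives an at least 1.3-fold higher number from compound 1 to compound 3 (0.13 log units; that floor lies within the scatter). Compound 3 gives > 10000 nM, which is a limit of the assay and not a number. So amino in place of methoxy at this position brings no lower number, but the step's floor cannot separate a real loss from ordinary scatter, and the set now leans heavily on one limit: the limit of > 10000 nM in this assay, at which 2 of the 3 values shown sit.

The compounds shown leave open how a hydroxyl, a methyl or a dimethylamino group in the same place would read, and whether any of them would fall below compound 1 at 7400 nM. Going by these compounds, how far the true value of compound 3 lies past its limit also stays open.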